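Acetyl for Dimethylamino on a Cyanomethyl Pyrazole Series

The source may hold more compounds than are shown below. What is called first, only, known or untested is meant among the compounds shown, and "the series" means these compounds.

Measured compounds:
compound 1 `COc1cc(C)cc(-c2c(-c3ccnc(-c4ccc(N(C)C)cc4)c3)cnn2CC#N)c1`: 9%
compound 2 `Cc1cc(O)cc(-c2nn(CC#N)cc2-c2ccnc(-c3ccc(N(C)C)cc3)c2)c1`: 24%

In a functional assay on IGROV-1 cells (Homo sapiens) for cytotoxicity, read by sulforhodamine B assay, with a stated time of 48 h, tested at 1 uM (on this read-out lower numbers stand for a stronger effect and higher numbers for a weaker effect at the one concentration tested), compound 1 gives 9%, the lowest of the two numbers recorded. Where compound 1 carries a methoxy on the methyl-bearing aryl ring, compound 2 carries a hydroxyl, and in this assay compound 2 gives 24%. Within the data shown here, that number is higher than the one for compound 1 and lies beyond the usual scatter of repeated measurements; the two compounds are not a single-point pair, so only their two values are compared here.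

Compound 3 `COc1cc(C)cc(-c2c(-c3ccnc(-c4ccc(C(C)=O)cc4)c3)cnn2CC#N)c1` has not yet been measured. It differs from compound 1 in one place: acetyl in place of dimethylamino on an aromatic carbon. Among the measured compounds shown here, no pair of measured compounds shows this change, so nothing in the numbers at hand tells how large a step it brings. Compound 3 is expected to give a somewhat weaker effect than compound 1, with the step of a number 13 percentage points higher from compound 1 to compound 3 (beyond the scatter) estimated as a moderate rise in this assay. The estimate for compound 3 is therefore 22%, within a range from 5% to 50%.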

Compound 3, a percentage reported as activity, at one concentration (the size of the read-out at that concentration, not a potency): 23%
Compound 3: middle estimate off by 1 percentage points, on the low side; measured number inside the range.
By their numbers in this assay, from the lowest: compound 1; then compounds 3 and 2 (each within the scatter of the next).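

In this assay, putting acetyl in place of dimethylamino on the aromatic carbon para to a large group gives a number 14 percentage points higher from compound 1 to compound 3 (beyond the scatter), so this position responds to a change of group and the 4-(dimethylamino)phenyl and 4-acetylphenyl groups cannot be exchanged there without a readable loss of effect. The earlier compounds could not show this: they are not a single-point pair, and neither departs from dimethylamino at this position, whereas here the leaving and entering groups have the same number of heavy atoms and the same counts of hydrogen-bond donors and acceptors, so those counts alone do not account for the difference between them. Nothing in the data at hand gives a reason for the step.

The compounds shown leave open how other groups would behave at this position, such as a primary amine, a carboxylic acid or a longer chain ending in dimethylamino. They also leave open whether the same exchange would bring a step of similar size on the core of compound 2, which carries a hydroxyl in place of the methoxy.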